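Compound 3: a new amide group on the carbonyl carbon

This account rests on a few compounds, and the source may have more. Where it says the series, first, only, none or still open, it means among the compounds named here.

Compound 1 `CS(=O)(=O)c1ccc(C(=O)NCCC(=O)N2CCCc3ccccc32)cc1[N+](=O)[O-]` gives 10500 nM
Compound 2 `CS(=O)(=O)c1ccc(C(=O)NCCC(=O)N2CCc3ccccc32)cc1[N+](=O)[O-]` gives > 27000 nM (a limit)

In an ADME assay on HepG2 cells (Homo sapiens) for cytotoxicity, read by CellTiter-Glo and ATP content, with a stated time of 72 h (a lower number here means that less compound is needed, a higher number that more compound is needed for the effect), compound 2 gives only a limit (> 27000 nM) and no number. Compound 3 `CC(C)N(C(=O)CCNC(=O)c1ccc(S(C)(=O)=O)c([N+](=O)[O-])c1)C(C)C` differs from it on the carbonyl carbon (diisopropylamino in place of 2,3-dihydro-1H-indol-1-yl on a carbonyl carbon). Within the data shown here, one measured step bears on this change, at the same kind of place: an at least 2.5-fold higher number from compound 1 to compound 2 (0.41 log units; beyond the scatter). That step gives no direction for a group with no ring, so no step beyond the scatter is expected, and the estimated step is an at least 1.1-fold lower number from compound 2 to compound 3 (0.05 log units; that floor lies within the scatter). The estimate for compound 3 is 24000 nM (expected range 12000 nM to 40000 nM).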

Compound 3, half-maximal effective concentration: > 27000 nM
Compound 3 ended at the assay's limit (the forecaster's own chance of this, stated with the estimate: 65%); middle value at least 1.1-fold (0.05 log units) away from the limit.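

In this assay, a group with no ring on the carbonyl carbon behaves like the ring-bearing replacement: diisopropylamino in place of 1,2,3,4-tetrahydroquinolin-1-yl gives an at least 2.5-fold higher number from compound 1 to compound 3 (0.41 log units; beyond the scatter). A ring in the amide group is therefore not required to reach the limit, since 2,3-dihydro-1H-indol-1-yl and diisopropylamino both end there. The step between compound 2 and compound 3 cannot be read: the limit of > 27000 nM in this assay, at which 2 of the 3 values shown sit.

Left open is whether a smaller open-chain amine such as dimethylamino, or a morpholine ring, on the carbonyl carbon would give a measurable number.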